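Extending an Alkoxy Chain on Two Related Cores

The compounds below may be only part of what the source reports. "The series", "measured", "known", "first", "only" and "open" are said of these compounds alone.

Compound 1 `CCCCOc1ccc(-c2[nH]c3ccccc3c2C2=C(Br)C(=O)NC2=O)cc1` was measured in a physicochemical assay for lipophilicity (a higher number here means a more lipophilic compound, a lower number a more polar compound), where compound 1 gives 3.87. Compound 2 `CCCCCOc1ccc(-c2[nH]c3ccccc3c2C2=C(Br)C(=O)NC2=O)cc1` carries one more carbon in its chain; in this assay compound 2 gives 4.2. The change between them, (methyl in place of hydrogen on a saturated chain carbon, four bonds along the chain from an oxygen on an aromatic ring), made a step of a number 0.33 log units higher from compound 1 to compound 2 (beyond the scatter).

Compound 3 `CCCCOc1ccc2[nH]c(-c3ccccc3)c(C3=C(Br)C(=O)NC3=O)c2c1` has the same atoms as compound 1 joined in a different way; the difference between the two cores is not broken down here. In this assay compound 3 gives 3.42, the lowest of the three numbers, with compound 1 nearer to it than compound 2.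

Compound 4 `CCCCCOc1ccc2[nH]c(-c3ccccc3)c(C3=C(Br)C(=O)NC3=O)c2c1` has not yet been measured. It differs from compound 3 by methyl in place of hydrogen on a saturated chain carbon, four bonds along the chain from an oxygen on an aromatic ring, which is the same change that turns compound 1 into compound 2, made at the same place. If the chain extension behaves on the core of compound 3 as it did on the core of compound 1, the step is estimated to be a number 0.33 log units higher from compound 3 to compound 4 (beyond the scatter), because the earlier change gave a number 0.33 log units higher from compound 1 to compound 2 (beyond the scatter). Whether the two cores respond alike to this change is not shown by any further compound, so the expectation carries some width. On that basis compound 4 is expected to give about 3.75 in this assay, most likely between 3.5 and 4.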

Compound 4, partition coefficient: 3.75
The estimate for compound 4 equals the measured number at the digits printed, and the stated range covers the measured number.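

The new step in this assay reads (a number 0.33 log units higher from compound 3 to compound 4 (beyond the scatter)), and the same change on the core of compound 1 reads (a number 0.33 log units higher from compound 1 to compound 2 (beyond the scatter)), so methyl in place of hydrogen, at this place on the saturated chain, gave steps that print alike on both cores. Going by these compounds alone, this supports carrying this one change, at this one place, from the core of compound 1 to the core of compound 3 in this read-out, but it rests on only two pairs of compounds and does not establish a rule for other changes, other places or other cores. Nothing given here accounts for the match between the two steps, which is recorded as an observation and not explained.

As far as these compounds go, whether the steps would stay alike for a longer chain, or with an amine or a carboxylic acid in place of the added methyl, remains open on both cores. The four compounds also leave open whether a third core would respond in the same way, and whether the match would extend to any read-out other than this assay at all.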